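The source may hold more compounds than are shown below. What is called first, only, known or untested is meant among the compounds shown, and "the series" means these compounds.

Compound 1 `CCCCOC(=O)N1CCC(Oc2ncnc3c2CCN3c2ccc(S(C)(=O)=O)cc2F)CC1`: in a functional assay on CHO-K1 cells with Glucose-dependent insulinotropic receptor (Homo sapiens) as the target, read by a luciferase reporter, with a stated time of 5 h (a lower number here means a smaller maximal response, a higher number a larger maximal response), compound 1 gives 131%.
Compound 2 `CC(C)(C)COC(=O)N1CCC(Oc2ncnc3c2CCN3c2ccc(S(C)(=O)=O)cc2F)CC1`: compound 2 gives 80%.
Compound 3 `CCSC(=O)N1CCC(Oc2ncnc3c2CCN3c2ccc(S(C)(=O)=O)cc2F)CC1`: compound 3 gives 128%.

Compound 3 stands second highest of the three; its value and that of compound 1 lie within the scatter of each other, while compound 2 is far lower, as a number 48 percentage points higher from compound 2 to compound 3 (beyond the scatter) shows. Compound 4 `CC(C)SC(=O)N1CCC(Oc2ncnc3c2CCN3c2ccc(S(C)(=O)=O)cc2F)CC1` differs from compound 3 by methyl in place of hydrogen on a saturated chain carbon bound to a saturated chain carbon and a sulfur. Going by the values given here, two measured steps bear on this. Exchanging butoxy for ethylsulfanyl changed little, a number 3 percentage points lower from compound 1 to compound 3 (within the scatter), whereas enlarging the chain on the oxygen side was costly, a number 51 percentage points lower from compound 1 to compound 2 (beyond the scatter). Adding a single carbon on the sulfur side is a smaller change than propyl to tert-butyl, so a modest downward step is expected, a number 18 percentage points lower from compound 3 to compound 4 (beyond the scatter), possibly within the scatter. Compound 4 is therefore estimated at 110%, with a range of 75% to 140%.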

Compound 4, largest response reached (reported as percent of maximum), in percent of the reference or control that the assay uses: 138%
For compound 4 the middle estimate is 28 percentage points below the measured one, within the range that was stated.
By their numbers in this assay, from the lowest: compound 2; then compounds 3, 1 and 4 (each within the scatter of the next).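

In this assay, methyl in place of hydrogen on the saturated chain carbon bound to a saturated chain carbon and a sulfur gives a step that stays within the scatter (a number 10 percentage points higher from compound 3 to compound 4 (within the scatter)), so this position accepts the isopropylsulfanyl group. That group also sits level with butoxy (a number 7 percentage points higher from compound 1 to compound 4 (within the scatter)) and keeps a large margin over neopentyloxy (a number 58 percentage points higher from compound 2 to compound 4 (beyond the scatter)). No measurement shown offers a reason for this. As far as these compounds go, it remains open whether a longer chain on the sulfur, or an amine on the carbonyl carbon, would hold this maximal response.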